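This account rests on a few compounds, and the source may have more. Where it says the series, first, only, none or still open, it means among the compounds named here.

Measured so far in a functional assay on HT-29 cells (Homo sapiens) for antiproliferative activity, with a stated time of 72 h; on this read-out lower numbers stand for stronger inhibition and higher numbers for weaker inhibition:
Compound 1 `COc1ccc(C2CC(c3ccccc3)=NN2c2nc(-c3ccccc3)c(C#N)c(=O)n2C)cc1` gives 14700 nM.
Compound 2 `Cn1c(N2N=C(c3ccccc3)CC2c2ccccc2)nc(-c2ccc(Cl)cc2)c(C#N)c1=O` gives 19500 nM.
Compound 3 `Cn1c(N2N=C(c3ccccc3)CC2c2ccc(Cl)cc2)nc(-c2ccc(Cl)cc2)c(C#N)c1=O` gives 15000 nM.

Within the data shown here, compound 3 holds the second highest of these three numbers, yet all three sit within the scatter of one another, so no compound can be called stronger or weaker. Compound 4 `COc1ccc(C2CC(c3ccccc3)=NN2c2nc(-c3ccc(Cl)cc3)c(C#N)c(=O)n2C)cc1` differs from compound 3 in a single place: methoxy in place of chloro on an aromatic carbon. Among the measured compounds shown here, one measured step touches that same aromatic carbon: a 1.3-fold lower number from compound 2 to compound 3 (0.11 log units; within the scatter), which swapped a hydrogen for a chloro and changed nothing beyond the scatter. Because a 1.3-fold lower number from compound 2 to compound 3 (0.11 log units; within the scatter) stayed within the scatter, a change at this carbon is expected to matter little again, giving no change at the digits printed from compound 3 to compound 4 (within the scatter). Compound 4 is therefore expected at 15000 nM, with a range from 7000 nM to 32000 nM.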

Compound 4, half-maximal inhibitory concentration: 11000 nM
Estimate against measurement, compound 4: 1.4-fold (0.13 log units) above, within the range that was stated.
By their numbers in this assay, from the lowest: compounds 4, 1, 3 and 2 (each within the scatter of the next).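

Methoxy in place of chloro gives a 1.4-fold lower number from compound 3 to compound 4 (0.13 log units; within the scatter), and methoxy in place of hydrogen gives a 1.8-fold lower number from compound 2 to compound 4 (0.25 log units; within the scatter), so hydrogen, chloro and methoxy cannot be told apart at this aromatic carbon in this assay. Chloro in place of hydrogen at a different aromatic carbon gives a 1.3-fold lower number from compound 1 to compound 4 (0.13 log units; within the scatter), and this swap reads alike in both settings: the same change on two cores in this assay, a 1.3-fold lower number (0.11 log units; within the scatter) from compound 2 to compound 3 and a 1.3-fold lower number (0.13 log units; within the scatter) from compound 1 to compound 4, 1.0-fold (0.01 log units) apart, within the scatter of two such steps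

Hydrogen, chloro and methoxy are the only groups shown at this carbon. From the compounds shown here alone, whether an amine or a carboxylic acid there would move the number beyond the scatter remains open.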